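The source may report more compounds than this note shows. Statements on the series, on what has been measured and on what is new or still open speak of the compounds shown alone.

Measured so far:
compound 1, `N#CC1=C(/N=C/Nc2ccc([N+](=O)[O-])cc2)N(c2ccccc2)C(=O)N2CCCCC(N3CCCC3)C12`, gives 32.1%;
compound 2, `N#CC1=C(/N=C/c2ccccc2)N(c2ccccc2)C(=O)N2CCCCC(N3CCCC3)C12`, gives 46.5%.

Both numbers come from a functional assay on the whole organism (strain albino) for inhibition, with Rattus norvegicus as the target, read by paw edema, with a stated time of 1 h, at a dose of 20 mmol/kg by the intraperitoneal route; a higher number here means more inhibition at the dose given (going by the name of the read-out), a lower number less inhibition. Of the two compounds, compound 2 stands highest; its nearest neighbour, compound 1, lies lower by the step of a number 14.4 percentage points higher from compound 1 to compound 2 (beyond the scatter), which is beyond the scatter.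

Compound 3, `COc1ccc(/C=N/C2=C(C#N)C3C(N4CCCC4)CCCCN3C(=O)N2c2ccccc2)cc1`, has not yet been measured. It differs from compound 2 in one place: methoxy in place of hydrogen on an aromatic carbon. Cut one bond further out, the same difference reads phenyl to 4-methoxyphenyl.

Among the compounds with values here, only one measured step exists, from compound 1 to compound 2, and it is of a different kind: it swaps phenyl for (4-nitrophenyl)amino on the carbon that carries the double bond to nitrogen, rather than adding a group to an aromatic ring. Within the data shown here, no measured pair shows what methoxy in place of hydrogen on that ring does in this assay. With nothing that speaks to the change, the expected step of a number 1.5 percentage points higher from compound 2 to compound 3 (within the scatter) is one that stays within the scatter, in no particular direction. The estimate for compound 3 is therefore 48%, with a range from 30% to 65%.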

Compound 3, a percentage reported as inhibition, in the whole organism at one dose (the size of the read-out at that dose, not a potency): 59.1%
Estimate against measurement, compound 3: 11.1 percentage points below; the range from low to high includes it.
By their numbers in this assay, from the lowest: compound 1; then compound 2; then compound 3.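

In this assay, within the data shown here, the step from hydrogen to methoxy on the aromatic carbon para to a large group is the first measured change on this ring, and it gives a number 12.6 percentage points higher from compound 2 to compound 3 (beyond the scatter) for a gain that is modest but beyond the scatter. This shows that the read-out is not indifferent to what sits at this ring carbon, something the earlier pair could not show because its change involved the (4-nitrophenyl)amino group on the carbon with a double bond to nitrogen. Replacing that same group with 4-methoxyphenyl gives a number 27 percentage points higher from compound 1 to compound 3 (beyond the scatter) and places compound 3 highest of the three, although nothing measured here explains the effect of methoxy.

A single group at a single ring position cannot show whether the gain belongs to methoxy in particular, or whether a hydroxyl group, a chlorine atom, a dimethylamino group or a longer ethoxy chain at the same carbon would behave alike. Also open is what methoxy would do at another carbon of the ring, and since each number comes from one dose, the compounds shown give no measure of potency.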